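This account rests on a few compounds, and the source may have more. Where it says the series, first, only, none or still open, it means among the compounds named here.

Working notes on the amide series. In an ADME assay on LLC-MK2 cells (Macaca mulatta) for cytotoxicity, read by spectrophotometry and crystal violet staining, with a stated time of 4 days (a higher number here means that more compound is tolerated, a lower number that less compound is tolerated), compound 1 `CC(C)n1ncc2c(C(=O)Nc3ncccn3)cc(-c3cccs3)nc21` gives 75000 nM. Compound 2 `CC(C)n1ncc2c(C(=O)Nc3c(F)cc(F)cc3F)cc(-c3cccs3)nc21` gives > 200000 nM, which is a limit of the assay and not a number. Compound 3 `CC(C)n1ncc2c(C(=O)Nc3ccccc3S(N)(=O)=O)cc(-c3cccs3)nc21` gives 25000 nM, the lowest number in the set, with compound 1 its nearest neighbour.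

The next structure, compound 4 `CC(C)n1ncc2c(C(=O)Nc3cccc(F)c3F)cc(-c3cccs3)nc21`, carries 2,3-difluorophenyl in place of 2-sulfamoylphenyl on an amide-type nitrogen. The closest measured step is an at least 8.0-fold lower number from compound 2 to compound 3 (0.90 log units; beyond the scatter), where 2-sulfamoylphenyl replaces 2,4,6-trifluorophenyl. Two further steps point the same way: a 3.0-fold lower number from compound 1 to compound 3 (0.48 log units; beyond the scatter) and an at least 2.6-fold higher number from compound 1 to compound 2 (0.42 log units; beyond the scatter). In all three, the compound with 2-sulfamoylphenyl sits lower and the one with 2,4,6-trifluorophenyl sits higher. Removing 2-sulfamoylphenyl should therefore raise the number in this assay beyond the scatter, although the match is only partial, since compound 4 has two fluorines where compound 2 has three. The expected change is a 4.4-fold higher number from compound 3 to compound 4 (0.64 log units; beyond the scatter). For compound 4 the estimated value is 110000 nM, expected to fall between 45000 nM and 200000 nM.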

Compound 4, half-maximal cytotoxic concentration: 75000 nM
Estimate against measurement, compound 4: 1.5-fold (0.17 log units) above; measured number inside the range.
By their numbers in this assay, from the lowest: compound 3; then compounds 1 and 4 (each within the scatter of the next). At a limit, above all of these: compound 2.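

In this assay, 2,3-difluorophenyl in place of 2-sulfamoylphenyl on the amide-type nitrogen gives a 3.0-fold higher number from compound 3 to compound 4 (0.48 log units; beyond the scatter), so the low position of compound 3 now holds against a second fluorinated phenyl group and not only against 2,4,6-trifluorophenyl. Fluorine on the phenyl ring does not by itself set the number at this position: replacing pyrimidin-2-yl with 2,3-difluorophenyl gives no change at the digits printed from compound 1 to compound 4 (within the scatter), whereas replacing 2,4,6-trifluorophenyl with it gives an at least 2.6-fold lower number from compound 2 to compound 4 (0.42 log units; beyond the scatter). The value of compound 2 is a limit, so the size of that last step has only a bound: the limit of > 200000 nM in this assay, at which 1 of the 4 values shown sits.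

On these data alone, how far compound 2 lies from compound 4 stays open. Also open, as far as these compounds go, is where an aminophenyl group, a carboxylic acid on the phenyl ring or a plain alkyl chain on this nitrogen would fall.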